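This account rests on a few compounds, and the source may have more. Where it says the series, first, only, none or still open, it means among the compounds named here.

Measured so far:
- Compound 1, `N=C(NCCCc1c[nH]cn1)NCCSC(c1ccccc1)c1ccccn1`, gives in a functional assay on cardiac atrium for agonist activity at histamine H2 receptor (Cavia porcellus) (on this read-out lower numbers stand for lower potency and higher numbers for higher potency (the scale is a negative logarithm)), the value 6.6
- Compound 2, `N=C(NCCCc1c[nH]cn1)NCCC(c1ccc(Br)cc1)c1ccccn1`, gives in this assay the value 7.48

Within the data shown here, of these two numbers, compound 2 stands highest; its only neighbour, compound 1, lies lower by a gap beyond the usual scatter. Among the measured compounds shown here, compounds 1 and 2 differ in more than one place, so their two values show only that compound 2 is the more potent of the pair, not which part of the structure accounts for it.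

Compound 3, `N=C(NCCCc1c[nH]cn1)NCCC(c1ccccn1)c1ccccn1`, has not yet been measured. It differs from compound 2 in one place: pyridin-2-yl in place of 4-bromophenyl on a saturated chain carbon bound to an aromatic carbon and a saturated chain carbon. For the measured compounds named here, no measured pair shows this kind of exchange, so no step of known size can guide the expectation. With one aromatic ring replaced by another of similar size and shape, a small loss seems more likely than a gain, though a result within the scatter would not surprise. Compound 3 is therefore estimated at 7, with a range from 6.3 to 7.7. This estimate means an expected step of a number 0.48 log units lower from compound 2 to compound 3 (beyond the scatter).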

Compound 3, negative logarithm of the half-maximal effective concentration: 6.9
For compound 3 the middle estimate is 0.10 log units above the measured one; the range from low to high includes it.
By their numbers in this assay, from the lowest: compounds 1 and 3 (each within the scatter of the next); then compound 2.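

In this assay, among these compounds, pyridin-2-yl in place of 4-bromophenyl on a saturated chain carbon bound to an aromatic carbon and a saturated chain carbon gives a number 0.58 log units lower from compound 2 to compound 3 (beyond the scatter) and is the first comparison here that changes a single place. It shows that this position is not indifferent to which six-membered aromatic ring it carries, even though the two groups are close in size, with one more heavy atom in the group that leaves. The exchange still alters two things at once, removing a bromine and placing a nitrogen in the ring, which adds a hydrogen-bond acceptor, and nothing measured here accounts for the drop in potency.

From the compounds shown here alone, what remains open is which of these two alterations carries the step, and a plain phenyl group at this place would separate them by keeping the all-carbon ring without the bromine. Whether bromine itself matters, or any group in that place on the ring would serve as well, could be tested with 4-chlorophenyl or 4-methoxyphenyl, and neither group appears among the compounds shown.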